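A few compounds are considered here, and "the series" means these few. Any claim that something is new, unique, unknown or untested is made for them only; others in the source may bear on it.

Measured in a functional assay on MGC-803 cells (Homo sapiens) for inhibition, read by MTT assay, with a stated time of 72 h; a higher number here means a weaker inhibitor, a lower number a stronger inhibitor:
- Compound 1 `FC(F)(F)c1ccc(CSc2nc(N3CCNCC3)cc(C(F)(F)F)n2)cc1`: 5870 nM
- Compound 2 `FC(F)(F)c1ccc(CSc2nc(Sc3ncccn3)cc(C(F)(F)F)n2)cc1`: 28600 nM

Compound 2 holds the higher of the two numbers. Compound 3 `FC(F)(F)c1ccc(CSc2nc(Sc3ccccn3)cc(C(F)(F)F)n2)cc1` has pyridin-2-yl in place of pyrimidin-2-yl on a sulfur. Going by the values given here, the only measured step, a 4.9-fold higher number from compound 1 to compound 2 (0.69 log units; beyond the scatter), is modest and exchanged piperazin-1-yl for (pyrimidin-2-yl)sulfanyl on an aromatic carbon. Among the compounds with values here, it therefore bears only indirectly, as no measured step exchanges these two rings. No step beyond the scatter is expected in this assay, with at most a slight drift toward a lower number. The step expected is a 1.3-fold lower number from compound 2 to compound 3 (0.11 log units; within the scatter). Compound 3 is estimated at 22000 nM, with an expected range of 9000 nM to 50000 nM.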

Compound 3, half-maximal inhibitory concentration: > 50000 nM
Compound 3 was reported as a limit; the forecaster's own chance of this, stated with the estimate: 5%; at least 2.2-fold (0.35 log units) between middle value and limit.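

In this assay compound 3 is reported only as a limit, not as a number: the limit of > 50000 nM in this assay, at which 1 of the 3 values shown sits. Changing the ring on the sulfur gives an at least 1.7-fold higher number from compound 2 to compound 3 (0.24 log units; that floor lies within the scatter) and so brings no gain, though that floor does not show a real loss. The comparison with piperazin-1-yl gives an at least 8.5-fold higher number from compound 1 to compound 3 (0.93 log units; beyond the scatter) and places (pyridin-2-yl)sulfanyl, like (pyrimidin-2-yl)sulfanyl, on the weaker side of compound 1.

Still open, on these data alone, is whether morpholin-4-yl or dimethylamino on that aromatic carbon would match piperazin-1-yl. Also open, as far as these compounds go, is whether a phenyl ring on the sulfur would differ from pyridin-2-yl.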